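From tert-butyl to propoxy on the shared core

This account rests on a few compounds, and the source may have more. Where it says the series, first, only, none or still open, it means among the compounds named here.

Measured so far in a functional assay on MLM cells (Homo sapiens) for cytotoxicity, using microsomes; on this read-out lower numbers stand for an effect already at smaller amounts and higher numbers for an effect only at larger amounts of compound:
Compound 1 `CCOc1ccc(/C=C/c2cc(OC)c(OC)c(OC)c2)cc1` gives 2.2 uM
Compound 2 `COc1cc(/C=C/c2ccc(C(C)(C)C)cc2)cc(OC)c1OC` gives > 25 uM as a limit

In this assay compound 2 stands at > 25 uM and this is a limit, not a number. Compound 3 `CCCOc1ccc(/C=C/c2cc(OC)c(OC)c(OC)c2)cc1` follows from compound 2 by one change, propoxy in place of tert-butyl on an aromatic carbon with propoxy in place of tert-butyl on an aromatic carbon, para to a large group.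

Among the measured compounds shown here, one measured step bears on this change. It is an at least 11-fold higher number from compound 1 to compound 2 (1.05 log units; beyond the scatter) with tert-butyl in place of ethoxy on an aromatic carbon, and its size rests on the limit of > 25 uM in this assay, at which 1 of the 2 values shown sits, as its upper end. The change to compound 3 removes that same tert-butyl and runs the other way, so a large move towards lower numbers is expected, back towards compound 1 at 2.2 uM in this assay as the nearest guide. This expectation rests on a single step.

The expected change is an at least 8.3-fold lower number from compound 2 to compound 3 (0.92 log units; beyond the scatter) in this assay as an estimate. In this assay the estimate for compound 3 is 3 uM (expected range 1 uM to 12 uM).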

Compound 3, concentration for half-maximal effect: > 25 uM
Compound 3 was reported as a limit; the forecaster's own chance of this, stated with the estimate: 10%; middle value at least 8.3-fold (0.92 log units) away from the limit.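

On this position, a single methyl added to the saturated chain, two bonds along the chain from an oxygen on an aromatic ring, gives an at least 11-fold higher number from compound 1 to compound 3 (1.05 log units; beyond the scatter) in this assay, so the move to higher numbers does not depend on tert-butyl entering the ring. Compound 3, which keeps an oxygen on that aromatic carbon and has the hydrogen-bond acceptor that tert-butyl lacks, gives > 25 uM, and this is a limit, so keeping that oxygen does not by itself hold the value near that of compound 1. The step between compound 2 and compound 3 cannot be read, since both values are limits and give no order between the two groups: the limit of > 25 uM in this assay, at which 2 of the 3 values shown sit.

On these data alone, how far compound 2 and compound 3 lie beyond that limit stays open, and so does any ranking of tert-butyl against propoxy. The compounds shown also leave open how a butoxy chain, a hydroxyl or an amine in this place would read in this assay.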